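Weak antiproliferative readings and the step to compound 3

This account rests on a few compounds, and the source may have more. Where it says the series, first, only, none or still open, it means among the compounds named here.

Among the measured compounds shown here, in a functional assay on MCF7 cells (Homo sapiens) for antiproliferative activity, read by CCK-8 assay, with a stated time of 48 h (on this read-out higher numbers stand for weaker inhibition and lower numbers for stronger inhibition), compound 2 `C/C=C/C(=O)NCCOc1ccc(Oc2c(-c3ccc(F)cc3)sc3cc(O)ccc23)cc1` gives 21700 nM, the only actual number so far. Compound 1 `O=C(CCCNCCOc1ccc(Oc2c(-c3ccc(F)cc3)sc3cc(O)ccc23)cc1)N1CCC1` reports only a limit, > 25000 nM. Compound 3 `O=C(/C=C/CNCCOc1ccc(Oc2c(-c3ccc(F)cc3)sc3cc(O)ccc23)cc1)N1CCC1` carries 3-((azetidin-1-yl)carbonyl)prop-2-en-1-yl in place of (prop-1-en-1-yl)carbonyl on an amine nitrogen. For the measured compounds named here, the one measured step that bears on this change is an at least 1.1-fold lower number from compound 1 to compound 2 (0.06 log units; that floor lies within the scatter), and it starts from the limit of > 25000 nM in this assay, at which 1 of the 2 values shown sits, so it fixes no firm size. The expected result is a 1.1-fold lower number from compound 2 to compound 3 (0.04 log units; within the scatter), a change no larger than the scatter. Compound 3 is estimated at 20000 nM, with an expected range of 9000 nM to 35000 nM.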

Compound 3, half-maximal inhibitory concentration: 7340 nM
Compound 3: middle estimate off by 2.7-fold (0.44 log units), on the high side, and the stated range ends above it.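

In this assay, 3-((azetidin-1-yl)carbonyl)prop-2-en-1-yl in place of (prop-1-en-1-yl)carbonyl on the amine nitrogen gives a 3.0-fold lower number from compound 2 to compound 3 (0.47 log units; beyond the scatter), the first step shown at this position that lies beyond the scatter. With the azetidin-1-yl carbonyl kept, 2-((azetidin-1-yl)carbonyl)ethenyl in place of 2-((azetidin-1-yl)carbonyl)ethyl gives an at least 3.4-fold lower number from compound 1 to compound 3 (0.53 log units; beyond the scatter), so the ethenyl link goes with the lower number. Compound 1 stands at a limit, not a number, so this size is only a floor: the limit of > 25000 nM in this assay, at which 1 of the 3 values shown sits.

The compounds shown leave open whether the azetidin-1-yl group is needed, as against a pyrrolidin-1-yl or dimethylamino group on the same carbonyl. As far as these compounds go, whether a longer chain would serve as well also stays open.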